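Swapping an Ester for a Cyclopropyl Amide

The compounds below may be only part of what the source reports. "The series", "measured", "known", "first", "only" and "open" are said of these compounds alone.

Compound 2 `CCOC(=O)/C=C/c1ccncc1-c1ccc2ccccc2c1` gives 8090 nM in a functional assay on MDA-MB-231 cells (Homo sapiens) for inhibition, read by sulforhodamine B assay, with a stated time of 72 h (on this read-out lower numbers stand for stronger inhibition of growth and higher numbers for weaker inhibition of growth), the only plain number shown here. Compound 1 `CCOC(=O)/C=C/c1ccncc1-c1ccc2c(cnn2C)c1` reaches only a limit of this assay, > 10000 nM, which is the limit of > 10000 nM in this assay, at which 1 of the 2 values shown sits. Compound 3 `O=C(/C=C/c1ccncc1-c1ccc2ccccc2c1)NC1CC1` has not yet been tested. It differs from compound 2 by cyclopropylamino in place of ethoxy on a carbonyl carbon. Going by the values given here, no measured pair shows such a change, so the step is expected to be modest, a 1.6-fold lower number from compound 2 to compound 3 (0.21 log units; within the scatter), leaning toward slightly stronger inhibition but not clearly beyond the scatter. Compound 3 is therefore estimated at about 5000 nM, expected to fall between 1500 nM and 16000 nM.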

Compound 3, concentration for 50% growth inhibition: 8420 nM
Compound 3: the middle estimate sits 1.7-fold (0.23 log units) below what was measured, within the range that was stated.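

Replacing ethoxy with cyclopropylamino on the carbonyl carbon gives a 1.0-fold higher number from compound 2 to compound 3 (0.02 log units; within the scatter) in this assay. This first measured step at this position shows that the two groups cannot be told apart here, even though cyclopropylamino brings a three-membered ring and a hydrogen-bond donor. Compound 1 remains at a limit of the assay: the limit of > 10000 nM in this assay, at which 1 of the 3 values shown sits.

Still open, on these data alone, is whether a carboxylic acid or a primary amide on this carbonyl carbon would give a step beyond the scatter. Also open, as far as these compounds go, is whether cyclopropylamino would read the same on the core of compound 1.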